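This account rests on a few compounds, and the source may have more. Where it says the series, first, only, none or still open, it means among the compounds named here.

Measured compounds:
compound 1, `C=C1[C@H](OC(C)=O)[C@@H](OC(=O)C(C)(C)C)[C@@H](OC(C)=O)C(C)(C)/C=C/[C@H](C)[C@H](OC(=O)c2ccccc2)[C@@]2(O)C[C@@](C)(O)[C@H](OC(C)=O)[C@@H]2[C@H]1OCC(C)C`: 1220 nM
compound 2, `C=C1[C@H](OC(C)=O)[C@@H](OC(=O)c2cccc(C)c2)[C@@H](OC(C)=O)C(C)(C)/C=C/[C@H](C)[C@H](OC(=O)c2ccccc2)[C@@]2(O)C[C@@](C)(O)[C@H](OC(C)=O)[C@@H]2[C@H]1OCC(C)C`: 980 nM
compound 3, `C=C1[C@H](OC(C)=O)[C@@H](OC(=O)c2cccc(C)c2)[C@@H](OC(C)=O)C(C)(C)/C=C/[C@H](C)[C@H]2O[C@]3(C)C[C@@]2(OC(=O)c2ccccc2)[C@H]([C@H]3OC(C)=O)[C@H]1OCC(C)C`: 6570 nM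

In a functional assay on NCI/ADR-RES cells (Homo sapiens) for positive allosteric modulation, read by MTT assay, with a stated time of 48 h, tested at 10 uM (a higher number here means a weaker inhibitor, a lower number a stronger inhibitor), compound 1 gives 1220 nM, compound 2 gives 980 nM and compound 3 gives 6570 nM. Compound 1 differs from compound 2 by one change:
tert-butyl in place of 3-methylphenyl on a carbonyl carbon
That change made the step of a 1.2-fold higher number from compound 2 to compound 1 (0.10 log units; within the scatter), so the two values are not separated by this assay.

Compound 4, `C=C1[C@H](OC(C)=O)[C@@H](OC(=O)C(C)(C)C)[C@@H](OC(C)=O)C(C)(C)/C=C/[C@H](C)[C@H]2O[C@]3(C)C[C@@]2(OC(=O)c2ccccc2)[C@H]([C@H]3OC(C)=O)[C@H]1OCC(C)C`, has not been measured. It differs from compound 3 by the same change, at the same place: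
tert-butyl in place of 3-methylphenyl on a carbonyl carbon
The core of compound 3 and the core of compound 2 differ as well, but that difference is not broken down here.

Compound 3 stands far from compound 1 and compound 2 in this assay, and compound 4 is expected to stay near it, because the earlier step of a 1.2-fold higher number from compound 2 to compound 1 (0.10 log units; within the scatter) hardly moved the number. The expected step is a 1.1-fold higher number from compound 3 to compound 4 (0.06 log units; within the scatter). For compound 4 the estimate is 7500 nM, expected to lie between 3000 nM and 19000 nM.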

Compound 4, half-maximal inhibitory concentration: 2750 nM
For compound 4 the middle estimate is 2.7-fold (0.44 log units) above the measured one; the whole stated range lies above it.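

Tert-butyl in place of 3-methylphenyl on the carbonyl carbon gave a 2.4-fold lower number from compound 3 to compound 4 (0.38 log units; beyond the scatter) in this assay. The size of this change therefore did not carry over from one core to the other: the same change on two cores in this assay, a 1.2-fold higher number (0.10 log units; within the scatter) from compound 2 to compound 1 and a 2.4-fold lower number (0.38 log units; beyond the scatter) from compound 3 to compound 4, 3.0-fold (0.47 log units) apart, beyond the scatter of two such steps

Among the compounds shown here, with only two matched pairs, this shows that a step measured on one of these cores cannot simply be copied to the other, but it does not show why the cores differ or how the change would behave on a further core. The compounds shown leave open what other groups on this carbonyl carbon would do on either core, such as a straight-chain alkyl group or a phenyl ring carrying an amine or a carboxylic acid. They also leave open which part of the difference between the two cores matters for this change.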